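The source may report more compounds than this note shows. Statements on the series, on what has been measured and on what is new or still open speak of the compounds shown alone.

Measured so far: compound 1 `O=c1ccn(COCCOP(=O)(O)O)c(=O)[nH]1` gives > 500000 nM; compound 2 `O=c1ccn(COCCOP(=O)(O)OP(=O)(O)OP(=O)(O)O)c(=O)[nH]1` gives 500000 nM; compound 3 `O=c1ccn(CCCCCOP(=O)(O)O)c(=O)[nH]1` gives 267000 nM.

All three were tested in a functional assay on NG108-15 cells for antagonist activity at P2Y purinoceptor 2 (Mus musculus), read by fluorescence and calcium flux, with a stated time of 30 min; a higher number here means a weaker inhibitor, a lower number a stronger inhibitor. For compound 1 the value of > 500000 nM is a limit of the assay, not a number, as noted in the limit of > 500000 nM in this assay, at which 1 of the 3 values shown sits. Compound 2 differs from compound 1 by a group of 8 heavy atoms (6 oxygen, 2 phosphorus; no ring) in place of a hydrogen atom, on an oxygen, and this gave a number no higher from compound 1 to compound 2 (the limit leaves the size open). Compound 3, with a different core, gives 267000 nM; the difference between its core and that of compound 1 is not broken down here. Compound 3 and compound 2 lie within the scatter of each other.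

Compound 4 `O=c1ccn(CCCCCOP(=O)(O)OP(=O)(O)OP(=O)(O)O)c(=O)[nH]1` has not yet been measured. It differs from compound 3 by a group of 8 heavy atoms (6 oxygen, 2 phosphorus; no ring) in place of a hydrogen atom, on an oxygen, the same kind of change as from compound 1 to compound 2, at a place described in the same words. Since the earlier step gave a number no higher, compound 4 is expected to show a step of a 1.3-fold lower number from compound 3 to compound 4 (0.13 log units; within the scatter), resting on that single earlier step and on the value of compound 3. The estimate for compound 4 is 200000 nM, between 80000 nM and 500000 nM.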

Compound 4, half-maximal inhibitory concentration: 500000 nM
For compound 4 the middle estimate is 2.5-fold (0.40 log units) below the measured one, within the range that was stated.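

In this assay, placing a group of 8 heavy atoms (6 oxygen, 2 phosphorus; no ring) on an oxygen in place of a hydrogen atom gives a 1.9-fold higher number from compound 3 to compound 4 (0.27 log units; within the scatter), so on this core the change leaves the reading within the scatter. Compound 1 gives > 500000 nM, which is a limit of the assay and not a number. The two steps therefore show no sign that the change acts differently on the two cores, but they do not show that it carries over unchanged: the same change on two cores in this assay, a number no higher (the limit leaves the size open) from compound 1 to compound 2 and a 1.9-fold higher number (0.27 log units; within the scatter) from compound 3 to compound 4; the limit leaves it open whether they differ

The compounds shown leave open how a single added phosphate unit, rather than the full group of 8 heavy atoms, would read in this assay, and how a longer chain would read on either core. They also leave open whether the same change would give a similar step on a core carrying an amine or a carboxylic acid.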